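The source may report more compounds than this note shows. Statements on the series, on what has been measured and on what is new or still open speak of the compounds shown alone.

Measured compounds in a functional assay on RAW264.7 cells (Mus musculus) for inhibition; on this read-out higher numbers stand for weaker inhibition and lower numbers for stronger inhibition:

compound 1 `O=C(c1ccc(CN2Cc3ccccc3C2=O)cc1)N1CCCCC1`, 21900 nM
compound 2 `CC(C)(C)OC(=O)N(Cc1ccco1)C(=O)c1ccc(CN2Cc3ccccc3C2=O)cc1`, 51800 nM
compound 3 `O=C(NCc1ccco1)c1ccc(CN2Cc3ccccc3C2=O)cc1`, 49700 nM

Compound 2 gives the highest of the three numbers in this assay, but its gap to compound 3 is small: a 1.0-fold lower number from compound 2 to compound 3 (0.02 log units; within the scatter). Against compound 1 it stands further off, and the only step that clears the scatter is a 2.3-fold higher number from compound 1 to compound 3 (0.36 log units; beyond the scatter), a modest one at the carbonyl end of the molecule.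

Compound 4 `CC(C)(C)OC(=O)N(Cc1ccco1)C(=O)c1ccc(Cn2oc3ccccc3c2=O)cc1` differs from compound 2 at the other end: a group of 10 heavy atoms (7 carbon, 1 nitrogen, 2 oxygen; one five-membered aromatic ring with 2 hetero atoms, one six-membered aromatic ring of carbon only) in place of a group of 10 heavy atoms (8 carbon, 1 nitrogen, 1 oxygen; one five-membered non-aromatic ring with 1 hetero atom, one six-membered aromatic ring of carbon only), on a saturated chain carbon bound to an aromatic carbon. Neither measured step touches this part of the structure; both concern the amide-type nitrogen and its substituents, so nothing measured here bears directly on the change from compound 2 to compound 4. The two steps that exist are small or within scatter, which gives no reason to expect a large shift from exchanging the group, but also no anchor for direction.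

In the absence of a comparable step, the expectation for compound 4 is a number close to that of compound 2, with a wide band: an estimated 50000 nM, ranging from 15000 nM to 160000 nM. The step this implies, a 1.0-fold lower number from compound 2 to compound 4 (0.02 log units; within the scatter), is expected to stay within the scatter.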

Compound 4, half-maximal inhibitory concentration: 6690 nM
Compound 4: the middle estimate sits 7.5-fold (0.87 log units) above what was measured, outside the stated range (below it).
By their numbers in this assay, from the lowest: compound 4; then compound 1; then compounds 3 and 2 (each within the scatter of the next).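

In this assay, within the data shown here, the first change at this end of the molecule, on a saturated chain carbon bound to an aromatic carbon, gives a 7.7-fold lower number from compound 2 to compound 4 (0.89 log units; beyond the scatter), whereas the amide-type nitrogen step a 1.0-fold lower number from compound 2 to compound 3 (0.02 log units; within the scatter) stays within the scatter. The number at this position therefore responds to the group placed there, even though both groups have 10 heavy atoms and one six-membered aromatic ring of carbon only; they differ in the five-membered ring, which is aromatic with 2 hetero atoms in the entering group and non-aromatic with 1 hetero atom in the group that leaves. No supporting evidence accounts for the shift, so it stands as an observation on this single pair.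

The compounds shown leave open whether the same exchange lowers the number when the amide-type nitrogen carries hydrogen or when the carbonyl carries piperidin-1-yl, as the single step comes from the tert-butoxycarbonyl compounds. They also leave open whether the aromatic five-membered ring, its second hetero atom or the ring system as a whole matters, and whether an open-chain amide or a carboxylic acid on the same chain carbon would give a comparable number.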